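A second trifluoromethyl on the weaker compound

A few compounds are considered here, and "the series" means these few. Any claim that something is new, unique, unknown or untested is made for them only; others in the source may bear on it.

Compound 1 `CC(O)(COc1cccc(S(F)(F)(F)(F)F)c1)C(=O)Nc1cccc(S(F)(F)(F)(F)F)c1` gives 10900 nM
Compound 2 `CC(O)(COc1cccc(C(F)(F)F)c1)C(=O)Nc1cccc(S(F)(F)(F)(F)F)c1` gives 28800 nM

In a functional assay on LNCaP cells (Homo sapiens) for antiproliferative activity, read by propidium iodide staining, with a stated time of 96 h (a lower number here means a stronger inhibitor, a higher number a weaker inhibitor), compound 2 has the higher of the two numbers, which makes it the weaker inhibitor. Going by the values given here, compound 3 `CC(O)(COc1cc(C(F)(F)F)cc(C(F)(F)F)c1)C(=O)Nc1cccc(S(F)(F)(F)(F)F)c1` has trifluoromethyl in place of hydrogen on an aromatic carbon of compound 2 as its only change (trifluoromethyl in place of hydrogen on an aromatic carbon). Among the compounds with values here, only one measured step bears on this, and only indirectly: a 2.6-fold higher number from compound 1 to compound 2 (0.42 log units; beyond the scatter) with a smaller group replacing a larger one. Within the data shown here, no measured pair shows a group added outright, so the expectation is uncertain. The expected change in this assay is a 2.1-fold lower number from compound 2 to compound 3 (0.31 log units; beyond the scatter) toward a lower number. The estimate for compound 3 is 14000 nM within an expected range of 5000 nM to 40000 nM.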

Compound 3, half-maximal inhibitory concentration: 2800 nM
Compound 3: the middle estimate sits 5.0-fold (0.70 log units) above what was measured; measured number below the stated range.
By their numbers in this assay, from the lowest: compound 3; then compound 1; then compound 2.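

Going by these compounds alone, with a 10-fold lower number from compound 2 to compound 3 (1.01 log units; beyond the scatter) in this assay, this is the first step here in which a group is added outright rather than exchanged for another, and the step is large. It shows that this place on the aromatic ring, meta to a trifluoromethyl group, strongly affects the number in this assay. Nothing available explains why the added trifluoromethyl has so large an effect. As far as these compounds go, whether a methyl or an amine at the same place would give a step of similar size stays open.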